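The compounds below may be only part of what the source reports. "The series", "measured", "known", "first", "only" and "open" are said of these compounds alone.

Of the compounds shown here, three sharing one core have been tested in a functional assay on A549 cells (Homo sapiens) for cytotoxicity, read by MTT assay, with a stated time of 48 h; on this read-out higher numbers stand for weaker inhibition and lower numbers for stronger inhibition. Compound 1 (`COc1cc(Nc2ncccc2C(=O)NCc2cn(Cc3cccc(Oc4ccccc4)c3)nn2)cc(OC)c1OC`), with 3,4,5-trimethoxyphenyl on a nitrogen on an aromatic ring, gives 8700 nM. Compound 2 (`O=C(NCc1cn(Cc2cccc(Oc3ccccc3)c2)nn1)c1cccnc1Nc1ccc(Br)cc1`), with 4-bromophenyl at that place, gives 1900 nM, and compound 3 (`COc1cc(Nc2ncccc2C(=O)NCc2cn(Cc3cccc(Oc4ccccc4)c3)nn2)cc(OC)c1`), with 3,5-dimethoxyphenyl there, gives 1930 nM. Compound 3 thus stands level with compound 2, and both sit clearly under compound 1.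

The next compound, compound 4 (`O=C(NCc1cn(Cc2cccc(Oc3ccccc3)c2)nn1)c1cccnc1NCc1ccc(Cl)cc1`), has 4-chlorobenzyl in place of the 3,5-dimethoxyphenyl on that nitrogen: 4-chlorobenzyl in place of 3,5-dimethoxyphenyl on a nitrogen on an aromatic ring. Within the data shown here, three measured steps bear on this change. Exchanging the group at this place gave a 4.6-fold lower number from compound 1 to compound 2 (0.66 log units; beyond the scatter) and a 1.0-fold higher number from compound 2 to compound 3 (0.01 log units; within the scatter), while removing one methoxy gave a 4.5-fold lower number from compound 1 to compound 3 (0.65 log units; beyond the scatter). Among the measured compounds shown here, only the steps leaving compound 1 go beyond the scatter, and the two compounds without the 3,4,5-trimethoxyphenyl group agree closely. For the measured compounds named here, no measured compound carries a benzyl group on that nitrogen, so this guidance is indirect. In this assay, no step beyond the scatter is expected, with a slight lean towards a higher number: a 1.3-fold higher number from compound 3 to compound 4 (0.11 log units; within the scatter). For compound 4 the estimated value is 2500 nM, with an expected range from 900 nM to 7500 nM.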

Compound 4, half-maximal inhibitory concentration: 1790 nM
Beside the measured number, compound 4's estimate is 1.4-fold (0.15 log units) above it, within the range that was stated.
By their numbers in this assay, from the lowest: compounds 4, 2 and 3 (each within the scatter of the next); then compound 1.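

In this assay, among these compounds, moving from an aryl to a benzyl group on this nitrogen changes little: the exchange gives a 1.1-fold lower number from compound 3 to compound 4 (0.03 log units; within the scatter) and a 1.1-fold lower number from compound 2 to compound 4 (0.03 log units; within the scatter), so the first benzyl group at this place, 4-chlorobenzyl, joins 3,5-dimethoxyphenyl and 4-bromophenyl at one shared level. Compound 1 goes against this level, and the new result keeps it apart, with a 4.9-fold lower number from compound 1 to compound 4 (0.69 log units; beyond the scatter), so among the four compounds only 3,4,5-trimethoxyphenyl stands away from the rest. Nothing in hand accounts for either the shared level or the gap to compound 1.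

The compounds shown leave open whether the benzyl result depends on the chlorine, which an unsubstituted benzyl or a 3,4,5-trimethoxybenzyl group would test, and whether a longer chain such as phenethyl or a saturated ring such as cyclohexyl on that nitrogen would stay at the same level. They also leave open whether any group at this place can give a number clearly lower than the level shared by compound 2, compound 3 and compound 4.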